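Hydroxamic Acid Ring Position and Histone Deacetylase Inhibition

The source may report more compounds than this note shows. Statements on the series, on what has been measured and on what is new or still open speak of the compounds shown alone.

Measured compounds:
compound 1, `O=C(NO)c1cccc(-c2cn([C@H]3C[C@H](CO)N(CCCc4ccccc4)C3)nn2)c1`, < 10%
compound 2, `O=C(NO)c1ccc(-c2cn([C@H]3C[C@H](CO)N(CCCc4ccccc4)C3)nn2)cc1`, 18%
compound 3, `O=C(NO)c1cccc(-c2cn([C@@H]3C[C@H](C(=O)O)N(CCCc4ccccc4)C3)nn2)c1`, < 10%

Three compounds share a triazole linked to a pyrrolidine bearing a phenylpropyl chain, and were tested in an assay on Sf9 cells for inhibition of histone deacetylase 11 (Homo sapiens), read by fluorescence, tested at 0.5 uM; on this read-out lower numbers stand for less inhibition and higher numbers for more inhibition at the one concentration tested (going by the name of the read-out). For compound 1 the value is a limit of the assay, < 10%. Compound 2 gives 18% in this assay. The change between them is 4-(hydroxycarbamoyl)phenyl in place of 3-(hydroxycarbamoyl)phenyl on an aromatic carbon, and it produced a number at least 8 percentage points higher from compound 1 to compound 2 (that floor lies within the scatter). For compound 3 the value is likewise a limit of the assay, < 10%; the difference between the core of compound 3 and that of compound 1 is not broken down here.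

Compound 4, `O=C(NO)c1ccc(-c2cn([C@@H]3C[C@H](C(=O)O)N(CCCc4ccccc4)C3)nn2)cc1`, has not yet been measured in this assay. It stands to compound 3 as compound 2 stands to compound 1: the change is 4-(hydroxycarbamoyl)phenyl in place of 3-(hydroxycarbamoyl)phenyl on an aromatic carbon, the same change, at the same place. The step from compound 3 to compound 4 is expected to be a number at least 5 percentage points higher from compound 3 to compound 4 (that floor lies within the scatter), resting on the step measured from compound 1 to compound 2, a number at least 8 percentage points higher from compound 1 to compound 2 (that floor lies within the scatter), and on the fact that the limit of < 10% in this assay, at which 2 of the 3 values shown sit, leaves compound 3 without a number to build on. Compound 4 is thus expected to give about 15% in this assay. Compound 4 is expected to fall between 5% and 30%.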

Compound 4, a percentage reported as inhibition, at one concentration (the size of the read-out at that concentration, not a potency): < 10%
Compound 4 ended at the assay's limit (the forecaster's own chance of this, stated with the estimate: 30%); middle value at least 5 percentage points away from the limit.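

In this assay, compound 3 and compound 4 both sit at a limit of the assay, so no step between them can be read, because neither has a number: the limit of < 10% in this assay, at which 3 of the 4 values shown sit.

The compounds shown leave open whether 4-(hydroxycarbamoyl)phenyl in place of 3-(hydroxycarbamoyl)phenyl changes inhibition at all on the core of compound 3.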